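A Pentyl Chain Added to Compound 3

The compounds below may be only part of what the source reports. "The series", "measured", "known", "first", "only" and "open" are said of these compounds alone.

Compound 3 `Cn1c(SCc2ccccc2)nnc1-c1cc([N+](=O)[O-])cc([N+](=O)[O-])c1` is one of three measured compounds, alongside compound 1 `O=[N+]([O-])c1cc(CSc2nnc(-c3ccccc3)n2C2CCCCC2)cc([N+](=O)[O-])c1` and compound 2 `O=[N+]([O-])c1cc(CSc2nnc(-c3ccccc3)n2Cc2ccccc2)cc([N+](=O)[O-])c1`. In an ADME assay on A-431 cells (Homo sapiens) for cytotoxicity, with a stated time of 48 h (on this read-out lower numbers stand for stronger inhibition and higher numbers for weaker inhibition), compound 1 gives only a limit, > 30000 nM. Compound 2 likewise gives only a limit in this assay, > 30000 nM. Compound 3 also gives only a limit in this assay, > 30000 nM. The step that the two limits leave unreadable from compound 1 to compound 2 is thus unreadable, and all three values sit at the limit of > 30000 nM in this assay, at which 3 of the 3 values shown sit. Compound 4 `CCCCCCn1c(SCc2ccccc2)nnc1-c1cc([N+](=O)[O-])cc([N+](=O)[O-])c1`, still to be measured in this assay, differs from compound 3 by pentyl in place of hydrogen on a saturated chain carbon bound to an aromatic nitrogen. No readable measured step bears on this change. The step that the limit leaves unreadable from compound 3 to compound 4 is expected to stay within the scatter, with compound 4 most likely again at a limit. Compound 4 is expected at 40000 nM, between 15000 nM and 120000 nM.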

Compound 4, half-maximal inhibitory concentration: > 30000 nM
Compound 4 was reported as a limit (the forecaster's own chance of this, stated with the estimate: 80%); the middle value lies beyond the limit too.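

Going by these compounds alone, compound 3 and compound 4 each stand only as a limit, so no step between them can be read: the limit of > 30000 nM in this assay, at which 4 of the 4 values shown sit. The compounds shown leave open whether any of them reaches a measurable value in this assay and what pentyl in place of hydrogen changes there.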